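This account rests on a few compounds, and the source may have more. Where it says the series, first, only, none or still open, it means among the compounds named here.

Measured so far in a functional assay (Cavia porcellus) with sulfonylurea receptors; K-ATP channels (Homo sapiens) as the target; a lower number here means a stronger inhibitor, a higher number a weaker inhibitor:
- compound 1 `CC(O)(C(=O)Nc1ccc(S(=O)(=O)c2cccc(O)c2)cc1)C(F)(F)F` gives 18000 nM
- compound 2 `CC(O)(C(=O)Nc1ccc(S(=O)(=O)c2ccc([N+](=O)[O-])cc2)cc1)C(F)(F)F` gives only a limit, > 30000 nM, that is the limit of > 30000 nM in this assay, at which 1 of the 3 values shown sits.
- compound 3 `CC(O)(C(=O)Nc1ccc(S(=O)(=O)c2ccccn2)cc1)C(F)(F)F` gives 600 nM

Compound 3 holds the lowest number of the two numbers shown; compound 1 is the nearest with a 30-fold lower number from compound 1 to compound 3 (1.48 log units; beyond the scatter) seen in the other direction, and compound 2 sits at a limit.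

The step under consideration is 1,3-thiazol-2-yl in place of pyridin-2-yl on a sulfonyl sulfur, giving compound 4 `CC(O)(C(=O)Nc1ccc(S(=O)(=O)c2nccs2)cc1)C(F)(F)F`. Both measured steps that end at compound 3 exchange the aryl on the sulfonyl sulfur: a 30-fold lower number from compound 1 to compound 3 (1.48 log units; beyond the scatter) and an at least 50-fold lower number from compound 2 to compound 3 (1.69 log units; beyond the scatter). Both are large and both run toward lower numbers when a six-membered heteroaryl bearing a ring nitrogen replaces a substituted phenyl. Among the measured compounds shown here, compound 4 keeps a ring nitrogen next to the sulfonyl-bearing carbon but moves to a five-membered ring with an added ring sulfur; no measured pair shows such a ring change, so its size cannot be taken from the data. Compound 3 is expected to be a fair guide, and compound 4 is therefore estimated at 800 nM in this assay, within 250 nM to 3000 nM, meaning an expected step of a 1.3-fold higher number from compound 3 to compound 4 (0.12 log units; within the scatter) that is judged to lie within the scatter.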

Compound 4, half-maximal inhibitory concentration: 1400 nM
Compound 4: the middle estimate sits 1.8-fold (0.24 log units) below what was measured; the range from low to high includes it.
By their numbers in this assay, from the lowest: compound 3; then compound 4; then compound 1. At a limit, above all of these: compound 2.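

In this assay, the sulfonyl sulfur accepts a five-membered aromatic ring as well as a six-membered one: with 1,3-thiazol-2-yl there is a 13-fold lower number from compound 1 to compound 4 (1.11 log units; beyond the scatter), so the large drop from 3-hydroxyphenyl is not confined to pyridin-2-yl. The comparison with compound 2 gives only a floor, an at least 21-fold lower number from compound 2 to compound 4 (1.33 log units; beyond the scatter), and compound 2 stands at a limit rather than a number: the limit of > 30000 nM in this assay, at which 1 of the 4 values shown sits. Exchanging one nitrogen-bearing ring for the other still registers, with a 2.3-fold higher number from compound 3 to compound 4 (0.37 log units; beyond the scatter), a modest step beyond the scatter, which leaves compound 3 with the lowest number of the four and shows that this position separates even two closely matched rings.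

On these data alone, whether the ring nitrogen drives the drop remains open, since an unsubstituted phenyl or a thiophene ring on the sulfonyl sulfur would be needed to separate its contribution from the loss of the hydroxy and nitro substituents. Also open, as far as these compounds go, is how much further the 1,3-thiazol-2-yl ring can be taken, for example with a methyl group or an amine attached to it.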